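Acyl chain variation on the shared core: cytotoxicity notes

The source may report more compounds than this note shows. Statements on the series, on what has been measured and on what is new or still open speak of the compounds shown alone.

Measured compounds:
- compound 1, `CCCCCCCCCCCC(=O)OC[C@@H]1OC[C@H](n2cc(C)c(=O)[nH]c2=O)O1`: in an ADME assay on CCRF-CEM cells (Homo sapiens) for cytotoxicity, read by MTT assay, with a stated time of 3 days (on this read-out lower numbers stand for stronger inhibition and higher numbers for weaker inhibition), compound 1 gives > 100000 nM, which is a limit of the assay.
- compound 2, `CCCCCCCCCCCCCCCC(=O)OC[C@@H]1OC[C@H](n2cc(C)c(=O)[nH]c2=O)O1`: in this assay compound 2 gives > 100000 nM, again a limit.
- compound 3, `CCCCCCCC(=O)OC[C@@H]1OC[C@H](n2cc(C)c(=O)[nH]c2=O)O1`: in this assay compound 3 gives > 100000 nM, also a limit.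

Compound 3 therefore stands nowhere in particular on the numbers shown: it sits, like the other two, at the limit of > 100000 nM in this assay, at which 3 of the 3 values shown sit, and no ranking among the three is possible. The steps between them are accordingly blank: a step that the two limits leave unreadable from compound 1 to compound 2, a step that the two limits leave unreadable from compound 1 to compound 3 and a step that the two limits leave unreadable from compound 2 to compound 3 leave no readable size in either direction.

The next compound is compound 4, `Cc1cn([C@H]2CO[C@@H](COC(=O)C3CC3)O2)c(=O)[nH]c1=O`. It differs from compound 3 by cyclopropyl in place of heptyl on a carbonyl carbon. The change shortens the acyl group from a seven-carbon chain to a three-membered ring, so it runs further in the direction already covered by the chain steps, all of which stayed at the limit.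

Nothing in the series points to a measurable number appearing on shortening the chain. The expected step that the limit leaves unreadable from compound 3 to compound 4 is therefore read as no departure from the limit. Compound 4 is estimated at 150000 nM, with a range of 40000 nM to 600000 nM, most likely reported again only as a limit.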

Compound 4, half-maximal inhibitory concentration: > 100000 nM
Compound 4 ended at the assay's limit; the forecaster's own chance of this, stated with the estimate: 80%; the middle value does not contradict the limit.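

No step can be read from compound 3 to compound 4, as both values are limits, and the series stays where it stood: the limit of > 100000 nM in this assay, at which 4 of the 4 values shown sit.

The compounds shown leave open whether any acyl group on the shared core gives a readable value in this assay, and how these four compounds rank among themselves.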